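This account rests on a few compounds, and the source may have more. Where it says the series, first, only, none or still open, it means among the compounds named here.

Measured compounds:
- compound 1, `O=C(Nc1ccc(-c2nn[nH]n2)cc1)c1cccc(-c2nn[nH]n2)c1`, 0.6 mg/kg in a functional assay on the whole organism (stomach) with Rattus norvegicus as the target; on this read-out higher numbers stand for an effect only at larger amounts of compound and lower numbers for an effect already at smaller amounts
- compound 2, `O=C(Nc1ccccc1)c1ccc(-c2nn[nH]n2)cc1`, 40 mg/kg
- compound 3, `O=C(Nc1ccccc1-c1nn[nH]n1)c1ccc(-c2nn[nH]n2)cc1`, 6.1 mg/kg

Among these three, compound 2 gives the highest number in this assay, so it is the one that needs the largest amount for its effect. Its nearest neighbour is compound 3, with a 6.6-fold lower number from compound 2 to compound 3 (0.82 log units; beyond the scatter), while compound 1 lies furthest away, with a still lower number than that of compound 3. Compound 2 carries a 2H-tetrazol-5-yl on one aromatic ring and a plain phenyl on the other, and the two compounds with lower numbers both carry a second 2H-tetrazol-5-yl.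

Compound 4, `N#Cc1ccc(NC(=O)c2ccc(-c3nn[nH]n3)cc2)cc1`, has not been measured yet. It differs from compound 2 by cyano in place of hydrogen on an aromatic carbon, placed on an aromatic carbon of a six-membered aromatic ring of carbon only, para to a large group. For the measured compounds named here, only one measured step bears on this: the step from compound 2 to compound 3 shows that adding a group to the phenyl ring of compound 2 lowered the number well beyond the scatter. Cyano is a much smaller group than 2H-tetrazol-5-yl and sits on a different position, so a smaller step is expected, still toward a lower number. For compound 4 the estimate is 15 mg/kg, within 4 mg/kg to 50 mg/kg, corresponding to an expected step of a 2.7-fold lower number from compound 2 to compound 4 (0.43 log units; beyond the scatter).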

Compound 4, dose for 50% inhibition: 19.7 mg/kg
Compound 4: the middle estimate sits 1.3-fold (0.12 log units) below what was measured; measured number inside the range.
By their numbers in this assay, from the lowest: compound 1; then compound 3; then compound 4; then compound 2.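

In this assay, the phenyl ring of compound 2 now shows a second change that lowers the number: a 2.0-fold lower number from compound 2 to compound 4 (0.31 log units; beyond the scatter). For the compounds shown here, until now the only such change on this ring was a 2H-tetrazol-5-yl, a group with a ring of its own, whereas cyano has no ring and only 2 heavy atoms, so a lower number on this ring does not depend on adding a second 2H-tetrazol-5-yl. The step is modest and lies only just beyond the usual scatter, which makes the place para to a large group one where a small group has a real but limited effect, and nothing available here accounts for the shift.

Compound 3 and compound 4 differ in both the added group and its place, so the contributions of group and place cannot be separated. The compounds shown also leave open whether a carboxylic acid or an amine at this same place would lower the number further, and whether cyano would give the same step elsewhere on the ring.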